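This account rests on a few compounds, and the source may have more. Where it says the series, first, only, none or still open, it means among the compounds named here.

Measured in a functional assay on HUVEC cells (Homo sapiens) for inhibition; on this read-out higher numbers stand for weaker inhibition and lower numbers for stronger inhibition:
- compound 1 `CN(c1ccc(NC(=O)Nc2ccc(OC(F)(F)F)cc2)cc1)c1ccnc(Nc2cccc(CS(C)(=O)=O)c2)n1`: 7 nM
- compound 2 `CCNC(=O)Nc1ccc(N(C)c2ccnc(Nc3cccc(CS(C)(=O)=O)c3)n2)cc1`: 3 nM

Compound 2 has the lower number of the pair, so it is the stronger inhibitor. Compound 3 `CCCCNC(=O)Nc1ccc(N(C)c2ccnc(Nc3cccc(CS(C)(=O)=O)c3)n2)cc1` differs from it by ethyl in place of hydrogen on a saturated chain carbon, two bonds along the chain from an amide-type nitrogen: ethyl in place of hydrogen on a saturated chain carbon, so ethyl becomes butyl. Going by the values given here, only one measured step bears on this: a 2.3-fold lower number from compound 1 to compound 2 (0.37 log units; beyond the scatter), a modest change that swapped a 4-(trifluoromethoxy)phenyl for ethyl on the amide-type nitrogen. Even with that far larger group, compound 1 gives 7 nM, so a large shift seems unlikely. The expected change is small, leaning upward and staying within the scatter: a 1.3-fold higher number from compound 2 to compound 3 (0.12 log units; within the scatter). For compound 3 the estimated value is 4 nM, with an expected range of 2 nM to 9 nM.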

Compound 3, half-maximal inhibitory concentration: 2 nM
Estimate against measurement, compound 3: 2.0-fold (0.30 log units) above, within the range that was stated.
By their numbers in this assay, from the lowest: compounds 3 and 2 (each within the scatter of the next); then compound 1.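

In this assay, butyl in place of ethyl on the amide-type nitrogen's chain gives a 1.5-fold lower number from compound 2 to compound 3 (0.18 log units; within the scatter), so this position takes the longer chain with no shift that stands out from the scatter. Butyl in place of 4-(trifluoromethoxy)phenyl gives a 3.5-fold lower number from compound 1 to compound 3 (0.54 log units; beyond the scatter), so the advantage over the aromatic group seen with ethyl holds for a second plain chain. Nothing measured here gives a reason for these numbers. Still open, from the compounds shown here alone, is how a longer chain such as octyl, or a chain ending in an amine or a carboxylic acid, would read at this position.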